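Aryloxymethyl sulfonamide series: naphthyl to tolyl ether

The source may hold more compounds than are shown below. What is called first, only, known or untested is meant among the compounds shown, and "the series" means these compounds.

In a functional assay on A549 cells (Homo sapiens) for cytotoxicity, read by MTT assay, with a stated time of 48 h (a lower number here means a stronger inhibitor, a higher number a weaker inhibitor), compound 3 `COc1cc2c(cc1OC)CN(S(=O)(=O)c1ccc(-n3cc(COc4ccc5ccccc5c4)nn3)cc1)CC2` gives only a limit, > 50 ug/mL. Compound 1 `COc1cc2c(cc1OC)CN(S(=O)(=O)c1ccc(-n3cc(COc4ccccc4C(C)=O)nn3)cc1)CC2` likewise returns a limit in this assay, > 50 ug/mL. Compound 2 `COc1cc2c(cc1OC)CN(S(=O)(=O)c1ccc(-n3cc(COc4ccc([N+](=O)[O-])cc4)nn3)cc1)CC2` also returns a limit here, > 50 ug/mL. All three values share (the limit of > 50 ug/mL in this assay, at which 3 of the 3 values shown sit), so the steps a step that the two limits leave unreadable from compound 1 to compound 3, a step that the two limits leave unreadable from compound 2 to compound 3 and a step that the two limits leave unreadable from compound 1 to compound 2 have no readable size or direction. Compound 4 `COc1cc2c(cc1OC)CN(S(=O)(=O)c1ccc(-n3cc(COc4ccc(C)cc4)nn3)cc1)CC2` differs from compound 3 by 4-methylphenyl in place of naphthalen-2-yl on an oxygen on a saturated carbon. For the measured compounds named here, none of the measured steps bears on this change with a readable size; the three aryl variants at this position all stop at the limit. The expected step here is a step that the limit leaves unreadable from compound 3 to compound 4, with no direction the data can support. Compound 4 is estimated at 60 ug/mL, with a range of 30 ug/mL to 120 ug/mL, and is expected most likely to be reported as a limit again.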

Compound 4, half-maximal inhibitory concentration: > 50 ug/mL
Compound 4: only a limit was reported; the forecaster's own chance of this, stated with the estimate: 80%; the middle value lies beyond the limit too.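

In this assay compound 4 returns only a limit, > 50 ug/mL. No step linking it to compound 1, compound 2 or compound 3 can be read: the limit of > 50 ug/mL in this assay, at which 4 of the 4 values shown sit.

Going by these compounds, whether any aryl group on this oxygen gives a readable value in this assay stays open.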